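The source may hold more compounds than are shown below. What is called first, only, known or untested is meant among the compounds shown, and "the series" means these compounds.

Measured in an ADME assay on the whole organism (strain FVB) for pharmacokinetics, with Mus musculus as the target, read by LC-MS, at a dose of 30 mg/kg by the oral route; a higher number here means more compound in the circulation at the dose given, a lower number less compound in the circulation:

- compound 1 `NCCOc1ccc([C@H]2CC[C@]3(CC2)OOC2(O3)C3CC4CC(C3)CC2C4)cc1`: 1370 ng.h/mL
- compound 2 `CC(C)(N)CCOc1ccc([C@H]2CC[C@]3(CC2)OOC2(O3)C3CC4CC(C3)CC2C4)cc1`: 12300 ng.h/mL
- compound 3 `c1cc([C@H]2CC[C@]3(CC2)OOC2(O3)C3CC4CC(C3)CC2C4)ccc1OCC1CCNCC1`: 4040 ng.h/mL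

Compound 3 holds the middle place of the three, with its 4040 ng.h/mL lying clearly apart from both neighbours: a 2.9-fold higher number from compound 1 to compound 3 (0.47 log units; beyond the scatter) and a 3.0-fold lower number from compound 2 to compound 3 (0.48 log units; beyond the scatter). Compound 4 `NCCCCOc1ccc([C@H]2CC[C@]3(CC2)OOC2(O3)C3CC4CC(C3)CC2C4)cc1` differs from compound 3 at one place: 3-aminopropyl in place of piperidin-4-yl on a saturated chain carbon bound to an oxygen on an aromatic ring. This puts 3-aminopropyl in place of piperidin-4-yl, so the ring gives way to an open chain. Within the data shown here, no measured step makes exactly this change. The nearest is a 2.9-fold higher number from compound 1 to compound 3 (0.47 log units; beyond the scatter), which also exchanges an open chain for piperidin-4-yl at that place. Compound 4 has an unbranched chain like compound 1, though a longer one. It lacks the 1-amino-1-methylethyl group behind a 9.0-fold higher number from compound 1 to compound 2 (0.95 log units; beyond the scatter), so that larger step offers little guidance here. A partial return towards the 1370 ng.h/mL of compound 1 therefore seems likely, and the expected change is small and downward: a 1.8-fold lower number from compound 3 to compound 4 (0.26 log units; within the scatter). For compound 4 the estimated value is 2200 ng.h/mL, with an expected range of 800 ng.h/mL to 6000 ng.h/mL.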

Compound 4, area under the concentration-time curve: 4700 ng.h/mL
The estimate for compound 4 lay 2.1-fold (0.33 log units) below the measured number, and the stated range covers the measured number.
By their numbers in this assay, from the lowest: compound 1; then compounds 3 and 4 (each within the scatter of the next); then compound 2.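

In this assay, 3-aminopropyl in place of piperidin-4-yl on a saturated chain carbon bound to an oxygen on an aromatic ring gives a 1.2-fold higher number from compound 3 to compound 4 (0.07 log units; within the scatter) here, so at this position an open chain serves as well as the ring. Lengthening the unbranched chain, with 2-aminoethyl in place of amino, gives a 3.4-fold higher number from compound 1 to compound 4 (0.54 log units; beyond the scatter) without any branching, yet 2-aminoethyl in place of 1-amino-1-methylethyl still gives a 2.6-fold lower number from compound 2 to compound 4 (0.42 log units; beyond the scatter) and so the branched chain of compound 2 stays ahead. Nothing given here accounts for these differences.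

The compounds shown leave open whether a still longer chain would hold this level or lose it. They also leave open what a tertiary amine, or a pyrrolidine ring in place of the piperidin-4-yl group, would do at this place.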